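The source may hold more compounds than are shown below. What is called first, only, known or untested is meant among the compounds shown, and "the series" means these compounds.

Measured so far: compound 1 `CC(C)(CCC/C=C(\c1ccccc1)c1cccnc1)C(=O)O` gives 21 nM in an assay (Equus caballus) for inhibition of Thromboxane-A synthase (Homo sapiens), using microsomes; a higher number here means a weaker inhibitor, a lower number a stronger inhibitor; compound 2 `O=C(O)C(CCC/C=C(\c1ccccc1)c1cccnc1)C1=CCCC1` gives 60 nM in this assay.

Compound 2 stands at the higher of the two numbers, with compound 1 lying beyond the scatter below it. The step to compound 3 `C=CCC(CCC/C=C(\c1ccccc1)c1cccnc1)C(=O)O` is allyl in place of cyclopent-1-en-1-yl on a saturated chain carbon bound to a carbonyl carbon and a saturated chain carbon. Within the data shown here, no comparable step between measured compounds has been made, so the expectation rests on these two values alone. Since compound 1 with its smaller substituent gives 21 nM, a modest drop from compound 2 is expected; compound 3 is estimated at 35 nM (range 12 nM to 100 nM), a step of a 1.7-fold lower number from compound 2 to compound 3 (0.23 log units; within the scatter) that may still fall within the scatter.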

Compound 3, half-maximal inhibitory concentration: 50 nM
Beside the measured number, compound 3's estimate is 1.4-fold (0.15 log units) below it; the measured number falls inside the stated range.
By their numbers in this assay, from the lowest: compound 1; then compounds 3 and 2 (each within the scatter of the next).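

In this assay, allyl in place of cyclopent-1-en-1-yl on this saturated chain carbon gives a 1.2-fold lower number from compound 2 to compound 3 (0.08 log units; within the scatter), so a ring is not required at this position to reach this level. The 1-carboxybut-3-en-1-yl group in place of 1-carboxy-1-methylethyl gives a 2.4-fold higher number from compound 1 to compound 3 (0.38 log units; beyond the scatter), which shows that the open-chain allyl group does not by itself match compound 1. No evidence here accounts for either step.

From the compounds shown here alone, it remains open whether propyl or cyclopentyl at this position would read like allyl or cyclopent-1-en-1-yl. A single methyl group there is also an open case.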